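The source may hold more compounds than are shown below. What is called first, only, known or untested is meant among the compounds shown, and "the series" means these compounds.

Working notes on the series built on the shared core of compound 1 `O=C(CCc1cccc2c1B(O)OC2)Nc1ccccc1`. In a functional assay on HCT-116 cells (Homo sapiens) for antiproliferative activity, read by MTT assay, with a stated time of 72 h (on this read-out higher numbers stand for weaker inhibition and lower numbers for stronger inhibition), compound 1 gives 350 nM. Compound 2 `O=C(CCc1cccc2c1B(O)OC2)Nc1nccs1` reads > 100000 nM, which is a limit of the assay and not a number. Compound 3 `O=C(CCc1cccc2c1B(O)OC2)Nc1ccc(Cl)cc1` gives 12000 nM, the higher of the two true numbers in this assay.

Compound 4 `O=C(CCc1cccc2c1B(O)OC2)Nc1ccc(I)cc1` follows from compound 3 by one change: iodo in place of chloro on an aromatic carbon, para to a large group.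

The measured step closest to this change is a 34-fold higher number from compound 1 to compound 3 (1.54 log units; beyond the scatter), a large step for chloro in place of hydrogen at that carbon. The other two steps, an at least 280-fold higher number from compound 1 to compound 2 (2.45 log units; beyond the scatter) and an at least 8.3-fold lower number from compound 2 to compound 3 (0.92 log units; beyond the scatter), replace the whole group on the amide-type nitrogen and bear on the question only indirectly. Among the measured compounds shown here, no measured step exchanges one halogen for another, so the size of this one is poorly constrained. Compound 4 keeps a halogen at the carbon where compound 3 carries one, so it is expected to stay near compound 3 rather than return towards compound 1 at 350 nM.

The expected change in this assay is none beyond the scatter, and the estimated step is a 1.3-fold higher number from compound 3 to compound 4 (0.10 log units; within the scatter). Compound 4 is estimated at 15000 nM, with an expected range of 3000 nM to 70000 nM.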

Compound 4, half-maximal inhibitory concentration: 50000 nM
The estimate for compound 4 lay 3.3-fold (0.52 log units) below the measured number; low and high end bracket the measured number.
By their numbers in this assay, from the lowest: compound 1; then compound 3; then compound 4. At a limit, above all of these: compound 2.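

In this assay, among the compounds shown here, the halogen on this aromatic carbon is not interchangeable: a 4.2-fold higher number from compound 3 to compound 4 (0.62 log units; beyond the scatter), the first measured exchange of one halogen for another, and a 140-fold higher number from compound 1 to compound 4 (2.15 log units; beyond the scatter), so the iodo compound sits further from the unsubstituted phenyl amide than the chloro compound does. Compound 2 stands at a limit of the assay, which is not a number: the limit of > 100000 nM in this assay, at which 1 of the 4 values shown sits. The step that rests on that limit, an at least 2.0-fold lower number from compound 2 to compound 4 (0.30 log units; that floor lies within the scatter), gives no order between the 4-iodophenyl and 1,3-thiazol-2-yl groups on the amide-type nitrogen, and so the new result adds nothing firm on that comparison.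

Across compound 1, compound 3 and compound 4, the numbers rise from hydrogen to chloro to iodo, but three compounds fix only this one sequence, and the values do not say what drives it. From the compounds shown here alone, whether fluoro or bromo would fall within that sequence remains open, as does how an amine or a carboxylic acid at the same carbon would read, and whether any group there can go below the value of the unsubstituted compound 1.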